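The source may hold more compounds than are shown below. What is called first, only, known or untested is meant among the compounds shown, and "the series" means these compounds.

The study compares a small set of triazole ethers in a physicochemical assay, read by spectrophotometry, with a stated time of 30 min; on this read-out higher numbers stand for weaker inhibition and lower numbers for stronger inhibition. Compound 1, `Cc1ccc(OCc2cn(Cc3ccc([N+](=O)[O-])cc3)nn2)cc1`, gives 10.9 ug/mL in this assay. Compound 2, `Cc1ccc(OCc2cn(Cc3ccc(Cl)cc3)nn2)cc1`, differs from compound 1 by chloro in place of nitro on an aromatic carbon and in this assay compound 2 gives 17.3 ug/mL. That change produced a 1.6-fold higher number from compound 1 to compound 2 (0.20 log units; within the scatter), so the two compounds are not separated by more than the usual run-to-run spread of this assay.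

Compound 3, `O=[N+]([O-])c1ccc(Cn2cc(COc3cccc([N+](=O)[O-])c3)nn2)cc1`, gives 17.1 ug/mL in this assay. Its core is not the core of compound 1; the difference between the two cores is not broken down here. The values of compound 3 and compound 2 sit essentially at the same level, and the values of compound 3 and compound 1 are likewise within the spread of this assay.

Compound 4, `O=[N+]([O-])c1cccc(OCc2cn(Cc3ccc(Cl)cc3)nn2)c1`, has not yet been measured in this assay. Among the compounds with values here, it differs from compound 3 by chloro in place of nitro on an aromatic carbon, which is the same change as the one made from compound 1 to compound 2, at a place described in the same words. Within the data shown here, since that earlier change gave a 1.6-fold higher number from compound 1 to compound 2 (0.20 log units; within the scatter), compound 4 is expected to give a number that differs from compound 3 by a 1.5-fold higher number from compound 3 to compound 4 (0.18 log units; within the scatter), a step of similar size and direction, resting on the single prior example and therefore uncertain. Compound 4 is accordingly estimated at 26 ug/mL in this assay, with a plausible range from 13 ug/mL to 52 ug/mL.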

Compound 4, half-maximal inhibitory concentration: 37.3 ug/mL
Beside the measured number, compound 4's estimate is 1.4-fold (0.16 log units) below it; the measured number falls inside the stated range.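

Chloro in place of nitro on an aromatic carbon moves the number the same way on both cores: the step on the core of compound 3 is a 2.2-fold higher number from compound 3 to compound 4 (0.34 log units; beyond the scatter), and the step on the core of compound 1 is a 1.6-fold higher number from compound 1 to compound 2 (0.20 log units; within the scatter). Only the first of these lies beyond the scatter, so the two pairs agree in direction, but the case for carrying the change from one core to another rests on a single modest step, and two pairs cannot show that the change would behave this way on any further core in the series. Nothing shown here bears on why the number rises with this change, or on whether the core has any influence on the size of the step.

The compounds shown carry only nitro or chloro at the changed place, which leaves open how an amine or a carboxylic acid there would read in this assay. They also leave open whether a third core would repeat the step, and what a longer chain in place of the methyl group of compound 2 would do to the number.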